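Chloro for cyano at the sulfur-ring carbon: compound 4

A few compounds are considered here, and "the series" means these few. Any claim that something is new, unique, unknown or untested is made for them only; others in the source may bear on it.

Measured in a functional assay on cells for agonist activity at Free fatty acid receptor 1 (Homo sapiens), read by FLIPR and calcium flux; a higher number here means that more compound is needed for the effect, a lower number that less compound is needed:
- compound 1 `CC#C[C@@H](Cc1nnn[nH]1)c1ccc(OCc2ccc3sc(F)c(-c4ccccc4C)c3c2)cc1`: 15 nM
- compound 2 `CC#C[C@@H](Cc1nnn[nH]1)c1ccc(OCc2ccc3scc(C4CCCCC4)c3c2)cc1`: 107 nM
- compound 3 `CC#C[C@@H](Cc1nnn[nH]1)c1ccc(OCc2ccc3sc(C#N)c(-c4ccccc4C)c3c2)cc1`: 16 nM

Compound 3 stands second highest of the three numbers; compound 1 lies within the scatter of it, while compound 2 gives a clearly higher number, beyond the scatter. Compound 4 `CC#C[C@@H](Cc1nnn[nH]1)c1ccc(OCc2ccc3sc(Cl)c(-c4ccccc4C)c3c2)cc1` differs from compound 3 by chloro in place of cyano on an aromatic carbon. Going by the values given here, the one measured step bearing on this position is a 1.1-fold higher number from compound 1 to compound 3 (0.03 log units; within the scatter), fluoro to cyano, which stayed within the scatter. Among the compounds with values here, no chloro analogue has been measured. Fluoro and cyano at this carbon give near-identical numbers, so chloro is expected to do likewise, a step of no change at the digits printed from compound 3 to compound 4 (within the scatter). Compound 4 is therefore estimated at 16 nM in this assay, with a range of 6 nM to 45 nM.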

Compound 4, half-maximal effective concentration: 20 nM
The estimate for compound 4 lay 1.3-fold (0.10 log units) below the measured number, within the range that was stated.
By their numbers in this assay, from the lowest: compounds 1, 3 and 4 (each within the scatter of the next); then compound 2.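

In this assay, the aromatic carbon next to the ring sulfur now carries a third group without a step beyond the scatter: cyano to chloro gives a 1.3-fold higher number from compound 3 to compound 4 (0.10 log units; within the scatter), and fluoro to chloro gives a 1.3-fold higher number from compound 1 to compound 4 (0.12 log units; within the scatter). Losing the triple bond and the hydrogen-bond acceptor of cyano thus leaves the number within the scatter. No measurement at hand explains why these groups read alike.

Still open, going by these compounds, is how this carbon responds to an amine, a carboxylic acid or a longer chain. Also open, on these data alone, is the number for plain hydrogen here with the 2-methylphenyl group kept.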